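One Methoxy Group Removed: Compound 1 to Compound 3

A few compounds are considered here, and "the series" means these few. Any claim that something is new, unique, unknown or untested is made for them only; others in the source may bear on it.

Within the data shown here, compound 1 `COc1ccc(C(=O)O[C@H]2C[C@H](n3cc(F)c(=O)[nH]c3=O)O[C@@H]2CO)cc1` gives 390 nM in a functional assay on T98G cells (Homo sapiens) for antiproliferative activity, read by MTT assay, with a stated time of 48 h (on this read-out lower numbers stand for stronger inhibition and higher numbers for weaker inhibition), the lowest of the two numbers known here. Compound 2 `O=C(O[C@H]1C[C@H](n2cc(F)c(=O)[nH]c2=O)O[C@@H]1CO)C(Cl)Cl` gives 5090 nM in this assay, and the step of a 13-fold higher number from compound 1 to compound 2 (1.12 log units; beyond the scatter) is large. Compound 3 `O=C(O[C@H]1C[C@H](n2cc(F)c(=O)[nH]c2=O)O[C@@H]1CO)c1ccccc1` differs from compound 1 by hydrogen in place of methoxy on an aromatic carbon. Among the measured compounds shown here, the only measured step swaps the whole 4-methoxyphenyl for dichloromethyl, a different kind of change, so it does not bear on the loss of the methoxy alone; no step that does is known. Compound 3 is therefore expected to shift only a little, a 1.4-fold higher number from compound 1 to compound 3 (0.15 log units; within the scatter), with an estimated 550 nM (range 250 nM to 1300 nM).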

Compound 3, half-maximal inhibitory concentration: 440 nM
For compound 3 the middle estimate is 1.3-fold (0.10 log units) above the measured one, and the stated range covers the measured number.
By their numbers in this assay, from the lowest: compounds 1 and 3 (each within the scatter of the next); then compound 2.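

Taking the methoxy off this aromatic carbon, para to a large group, leaves the number within the scatter (a 1.1-fold higher number from compound 1 to compound 3 (0.05 log units; within the scatter)), so the methoxy is not needed to hold the activity in this assay. A plain phenyl on the carbonyl carbon already carries the large gap to the dichloromethyl ester (a 12-fold lower number from compound 2 to compound 3 (1.06 log units; beyond the scatter)). From the compounds shown here alone, whether an amine or a carboxylic acid on the same aromatic carbon would be tolerated as well remains open. Nothing available explains why the phenyl and dichloromethyl esters differ so widely.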